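This account rests on a few compounds, and the source may have more. Where it says the series, first, only, none or still open, it means among the compounds named here.

Compound 1 `Cc1nnsc1CO/N=C/c1c(C)nn(C)c1Oc1ccc(OC(F)(F)F)cc1` is the starting point. In a functional assay on SGC-7901 cells (Homo sapiens) for inhibition, read by MTT assay, with a stated time of 48 h (a lower number here means a stronger inhibitor, a higher number a weaker inhibitor), compound 1 gives 11500 nM. Compound 2 `CCc1nnsc1CO/N=C/c1c(C)nn(C)c1Oc1ccc(OC(F)(F)F)cc1` carries one more carbon on its side chain; in this assay compound 2 gives 13600 nM. The change between them is methyl in place of hydrogen on a saturated chain carbon bound to an aromatic carbon, and the step it made is a 1.2-fold higher number from compound 1 to compound 2 (0.07 log units; within the scatter), so the two values are indistinguishable for practical purposes.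

Compound 3 `CCc1nnsc1CO/N=C/c1c(C)nn(C)c1Cl` has a different core; the difference between the two cores is not broken down here. In this assay compound 3 gives > 50000 nM, which is a limit of the assay and not a number, as the limit of > 50000 nM in this assay, at which 1 of the 3 values shown sits, shows.

Compound 4 `CCCc1nnsc1CO/N=C/c1c(C)nn(C)c1Cl` has not yet been measured. It differs from compound 3 by methyl in place of hydrogen on a saturated chain carbon, two bonds along the chain from an aromatic carbon. Within the data shown here, this is the same kind of change as the one from compound 1 to compound 2, but not the same: in the earlier pair the new carbon sits on a saturated chain carbon bound to an aromatic carbon, while here it sits on a saturated chain carbon two bonds along the chain from an aromatic carbon.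

Given that the earlier step of this kind stayed within the scatter, the expected step from compound 3 to compound 4 is a step that the limit leaves unreadable from compound 3 to compound 4, resting on a 1.2-fold higher number from compound 1 to compound 2 (0.07 log units; within the scatter) and on the limit of compound 3 at > 50000 nM. Compound 4 is therefore expected to give about 60000 nM, most likely again reported only as a limit, with a plausible range from 30000 nM to 150000 nM.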

Compound 4, half-maximal inhibitory concentration: > 50000 nM
Compound 4: a limit, no number; the forecaster's own chance of this, stated with the estimate: 80%; the middle value is on the limit's open side.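

In this assay compound 3 and compound 4 each give only a limit of the assay and not a number, so no step between them can be read: the limit of > 50000 nM in this assay, at which 2 of the 4 values shown sit.

The compounds shown leave open what the actual values of compound 3 and compound 4 are, and whether going from ethyl to propyl makes any difference on this core.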